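This account rests on a few compounds, and the source may have more. Where it says the series, first, only, none or still open, it means among the compounds named here.

Among the measured compounds shown here, compound 2, with the structure `O=C(NO)c1ccc(CN(Cc2nnnn2Cc2ccccc2)C(=O)c2ccccc2)cc1`, stands lowest of the two numbers measured so far: in an assay on isolated protein for inhibition of protein deacetylase HDAC6 (Homo sapiens), read by fluorescence, with a stated time of 90 min (a lower number here means a stronger inhibitor, a higher number a weaker inhibitor), compound 2 gives 30 nM. For the measured compounds named here, its only neighbour on this scale is compound 1, with the structure `Cc1cc(C)cc(C(=O)N(Cc2ccc(C(=O)NO)cc2)Cc2nnnn2Cc2ccccc2)c1`, which in this assay gives 80 nM. Going by the values given here, the single step between them, a 2.7-fold lower number from compound 1 to compound 2 (0.43 log units; beyond the scatter), comes from putting a phenyl in place of a 3,5-dimethylphenyl on the carbonyl carbon, so stripping two methyl groups from that ring gave the lower number.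

Compound 3, with the structure `CC(C)c1ccc(C(=O)N(Cc2ccc(C(=O)NO)cc2)Cc2nnnn2Cc2ccccc2)cc1`, differs from compound 2 by isopropyl in place of hydrogen on an aromatic carbon, on an aromatic carbon of the six-membered ring of carbon only, para to a large group. Among the compounds with values here, only one measured step bears on this change, and it runs the other way: adding carbon groups to the same ring raised the number in compound 1 compared with compound 2. A modest rise is therefore expected, not a fall, with the step of a 2.0-fold higher number from compound 2 to compound 3 (0.30 log units; within the scatter) carrying the expectation. The number for compound 3 in this assay is estimated at 60 nM, within a range from 25 nM to 150 nM.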

Compound 3, half-maximal inhibitory concentration: 320 nM
Compound 3: middle estimate off by 5.3-fold (0.73 log units), on the low side, outside the stated range (above it).
By their numbers in this assay, from the lowest: compound 2; then compound 1; then compound 3.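

In this assay, placing an isopropyl on this aromatic carbon, para to a large group, gives an 11-fold higher number from compound 2 to compound 3 (1.03 log units; beyond the scatter) and counts as a large step. The earlier change on the same ring was only modest, so the first pair gave no sign that one added group could cost this much. The two substituted rings also differ clearly from each other, with a 4.0-fold higher number from compound 1 to compound 3 (0.60 log units; beyond the scatter) on going from 3,5-dimethylphenyl to 4-isopropylphenyl, so the outcome depends on the particular substitution and not only on whether carbon groups are present on the ring. Nothing available here explains the size of this rise.

Because compound 1 and compound 3 differ in both the group and its place on the ring, these compounds cannot separate the effect of the group from the effect of its position. Going by these compounds, it remains open whether a smaller methyl on the same carbon would give a smaller rise, whether an isopropyl elsewhere on the ring would give the same rise, and how an amine or a carboxylic acid at this position would read.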